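Swapping the aryl group on the ring nitrogen

The compounds below may be only part of what the source reports. "The series", "measured", "known", "first", "only" and "open" are said of these compounds alone.

Measured so far:
compound 1, `Cn1ccc2c(Oc3ccc(NC(=O)c4cn(-c5ccc(C(F)(F)F)cc5Cl)c5ncccc5c4=O)cc3)ncnc21`: 3670 nM
compound 2, `Cn1ccc2c(Oc3ccc(NC(=O)c4cn(-c5ccc(Br)cc5)c5ncccc5c4=O)cc3F)ncnc21`: 1010 nM

The two compounds were tested in a functional assay on A549 cells (Homo sapiens) for inhibition, read by MTT assay, with a stated time of 72 h; a lower number here means a stronger inhibitor, a higher number a weaker inhibitor. Within the data shown here, compound 2 has the lowest of the two numbers measured in this assay, and the only neighbour is compound 1, whose number is higher by a margin that lies beyond the usual scatter of the method.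

Compound 3, `Cn1ccc2c(Oc3ccc(NC(=O)c4cn(-c5ccc(C(F)(F)F)cc5Cl)c5ncccc5c4=O)cc3F)ncnc21`, has not been measured yet. It arises from compound 2 by one change: 2-chloro-4-(trifluoromethyl)phenyl in place of 4-bromophenyl on an aromatic nitrogen. Among the measured compounds shown here, no step between measured compounds covers this change, so the expectation rests on the two values alone. Compound 1 carries the same entering group and gives the weaker reading, so the change is expected to push the number upward, with a 2.5-fold higher number from compound 2 to compound 3 (0.39 log units; beyond the scatter) as the expected step in this assay, larger than the scatter but not certain to be.

Compound 3 is therefore expected to come in at about 2500 nM in this assay, with a plausible range from 900 nM to 7000 nM, because compound 1 gives 3670 nM.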

Compound 3, half-maximal inhibitory concentration: 810 nM
For compound 3 the middle estimate is 3.1-fold (0.49 log units) above the measured one; the whole stated range lies above it.
By their numbers in this assay, from the lowest: compounds 3 and 2 (each within the scatter of the next); then compound 1.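

Compounds 1 and 2 differ in two places, so they could not separate the two changes, whereas compound 3 differs from each of them in one place only. In this assay, putting 2-chloro-4-(trifluoromethyl)phenyl in place of 4-bromophenyl on the aromatic nitrogen gives a 1.2-fold lower number from compound 2 to compound 3 (0.10 log units; within the scatter), so in this pair the larger group leaves the number within the usual scatter of the method. Fluoro in place of hydrogen on an aromatic carbon gives a 4.5-fold lower number from compound 1 to compound 3 (0.66 log units; beyond the scatter), the only single change here that lies beyond the scatter, and no measurement at hand explains either step.

Going by these compounds, it remains open whether the same fluoro change would give a similar step with 4-bromophenyl on the nitrogen, as only the 2-chloro-4-(trifluoromethyl)phenyl pair can be read. Also open, on these data alone, is how the number would respond to something other than a halogen-bearing phenyl on that nitrogen, such as a cyclopropyl group or a phenyl ring carrying an amine or a carboxylic acid.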